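A few compounds are considered here, and "the series" means these few. Any claim that something is new, unique, unknown or untested is made for them only; others in the source may bear on it.

Series notes. Compound 1 `CCOc1ccccc1N1CCN(CCCNc2ncccc2C(=O)N(C)C)CC1` gives 7.94 nM in a functional assay on aorta for antagonist activity at Alpha-1D adrenergic receptor (Rattus norvegicus); on this read-out lower numbers stand for tighter binding and higher numbers for weaker binding; compound 2 `CN(C)C(=O)c1cccnc1NCCCN1CCN(c2ccccc2OCC2CC2)CC1` gives 10 nM in this assay; compound 3 `CN(C)C(=O)c1cccnc1NCCCN1CCN(c2ccccc2OCC(C)(C)C)CC1` gives 50.1 nM in this assay and holds the highest number of the three. The steps measured so far are a 1.3-fold higher number from compound 1 to compound 2 (0.10 log units; within the scatter), a 6.3-fold higher number from compound 1 to compound 3 (0.80 log units; beyond the scatter) and a 5.0-fold higher number from compound 2 to compound 3 (0.70 log units; beyond the scatter). The next step, to compound 4 `Cc1ccccc1N1CCN(CCCNc2ncccc2C(=O)N(C)C)CC1`, is methyl in place of neopentyloxy on an aromatic carbon. The measured steps vary only the group on the saturated chain carbon bound to the oxygen on the aromatic ring; none removes that oxygen, so they bear on this change only indirectly. Because a 6.3-fold higher number from compound 1 to compound 3 (0.80 log units; beyond the scatter) and a 5.0-fold higher number from compound 2 to compound 3 (0.70 log units; beyond the scatter) both went toward higher numbers, a return to a small group is expected to give a somewhat lower number, with wide uncertainty. For compound 4 the estimate in this assay is 25 nM, range 6 nM to 100 nM. The expected step is a 2.0-fold lower number from compound 3 to compound 4 (0.30 log units; within the scatter).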

Compound 4, dissociation constant: 10 nM
Compound 4: the middle estimate sits 2.5-fold (0.40 log units) above what was measured, within the range that was stated.
By their numbers in this assay, from the lowest: compounds 1, 2 and 4 (each within the scatter of the next); then compound 3.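

Methyl in place of ethoxy gives a 1.3-fold higher number from compound 1 to compound 4 (0.10 log units; within the scatter) and methyl in place of cyclopropylmethoxy gives no change at the digits printed from compound 2 to compound 4 (within the scatter) so the oxygen on this aromatic carbon can be lost from these two compounds without a step beyond the scatter in this assay as the read-out. Neopentyloxy alone stands apart, with a 5.0-fold lower number from compound 3 to compound 4 (0.70 log units; beyond the scatter) as the step that shows it. Nothing at hand accounts for this tolerance.

Still open, from the compounds shown here alone, is whether a chlorine atom, an amine or a hydrogen on this aromatic carbon would fit the same picture. A longer chain in place of methyl is equally untested here.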